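Ester side chain variation

The compounds below may be only part of what the source reports. "The series", "measured", "known", "first", "only" and "open" are said of these compounds alone.

Among the measured compounds shown here, compound 2 `NCc1ccc(C(=O)Nc2ccncc2F)cc1-c1cccc(C(=O)OC2CCCOC2)c1` gives 0.3 h in an ADME assay on a cell-free system (plasma, Homo sapiens) for metabolic stability, read by LC-MS (on this read-out lower numbers stand for a shorter-lived compound and higher numbers for a longer-lived compound), the lowest of the two numbers so far; its nearest neighbour is compound 1 `CCCOC(=O)c1cccc(-c2cc(C(=O)Nc3ccncc3F)ccc2CN)c1`, which gives 0.317 h, and the two differ by a 1.1-fold lower number from compound 1 to compound 2 (0.02 log units; within the scatter). Compound 3 `NCc1ccc(C(=O)Nc2ccncc2F)cc1-c1cccc(C(=O)OCCO)c1` carries the change (2-hydroxyethyl in place of oxan-3-yl on an oxygen next to a carbonyl group). For the measured compounds named here, the only step that bears on this, at the same oxygen next to a carbonyl group, is a 1.1-fold lower number from compound 1 to compound 2 (0.02 log units; within the scatter), which did not move this assay beyond the scatter. Compound 3 is therefore expected to show no step beyond the scatter, about no change at the digits printed from compound 2 to compound 3 (within the scatter). The estimate for compound 3 is 0.3 h, within 0.15 h to 0.6 h.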

Compound 3, half-life: 1.35 h
Compound 3: middle estimate off by 4.5-fold (0.65 log units), on the low side; the measured number lies above the stated range.
By their numbers in this assay, from the lowest: compounds 2 and 1 (each within the scatter of the next); then compound 3.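

In this assay the group on this oxygen does matter: 2-hydroxyethyl in place of oxan-3-yl gives a 4.5-fold higher number from compound 2 to compound 3 (0.65 log units; beyond the scatter), and hydroxy in place of methyl on the chain gives a 4.3-fold higher number from compound 1 to compound 3 (0.63 log units; beyond the scatter). Propyl and oxan-3-yl lie within the scatter of each other, so of these three groups only 2-hydroxyethyl, the one with a hydrogen-bond donor, stands apart. Nothing at hand accounts for this step. On these data alone, whether the hydroxy itself is what counts stays open: 2-methoxyethyl, 2-aminoethyl or a longer hydroxyalkyl chain on the same oxygen would separate this from the loss of the ring.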